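A few compounds are considered here, and "the series" means these few. Any claim that something is new, unique, unknown or untested is made for them only; others in the source may bear on it.

In a functional assay on MM1.S cells (Homo sapiens) for cytotoxicity, read by MTT assay, with a stated time of 48 h (a lower number here means a stronger inhibitor, a higher number a weaker inhibitor), compound 1 (`CC(C)(C)NN=C1C(Cl)=C(Cl)C(Cl)=C1Cl`) gives > 3000 nM and this is a limit of the assay, not a number. Compound 2 (`CC(=O)NN=C1C(Cl)=C(Cl)C(Cl)=C1Cl`) has no number of its own: its result reads "not determined" (no result reported) and so it has no place on the scale. Compound 3 (`CN(C)N=C1C(Cl)=C(Cl)C(Cl)=C1Cl`) carries dimethylamino in place of acetamido on a double-bonded nitrogen. Counted out, the change is dimethylamino in place of acetamido on a double-bonded nitrogen and nothing else differs. Among the measured compounds shown here, no measured step exists to size this change, so no shift in this assay beyond the scatter is expected. Compound 3 is estimated to give 4000 nM (expected range 1000 nM to 15000 nM).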

Compound 3, half-maximal inhibitory concentration: > 3000 nM
Compound 3: no number, only a limit; the forecaster's own chance of this, stated with the estimate: 60%; the middle value is on the limit's open side.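

No step can be read from compound 1 to compound 3 in this assay, since both results are limits and not numbers: the limit of > 3000 nM in this assay, at which 2 of the 3 values shown sit. The compounds shown leave open where either compound truly lies on the scale, and whether dimethylamino or (tert-butyl)amino gives the stronger inhibitor.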